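Cytotoxicity notes: ester, acid and aryl substituent exchange

The source may report more compounds than this note shows. Statements on the series, on what has been measured and on what is new or still open speak of the compounds shown alone.

Of the compounds shown here, three on a shared core have been measured in a functional assay on EA.hy 926 cells (Homo sapiens) for cytotoxicity, read by MTT assay, with stated times of 24 h and 12 h, tested at 100 uM; on this read-out lower numbers stand for a weaker effect and higher numbers for a stronger effect at the one concentration tested. Compound 1 `COc1cc(/C=C/C(=O)O)ccc1OC(=O)c1nc(C)c(C)nc1C` gives 55.4%. Compound 2 `COc1ccc(OC(=O)c2nc(C)c(C)nc2C)c(/C=C/C(=O)O)c1` gives 79.2%. Compound 3 `CCOC(=O)/C=C/c1cc(OC)ccc1OC(=O)c1nc(C)c(C)nc1C` gives 46.2%, the lowest of the three numbers; its gap to compound 1 lies within the scatter, its gap to compound 2 lies beyond it. Within the data shown here, the single one-place step recorded so far is a number 33 percentage points lower from compound 2 to compound 3 (beyond the scatter), ethyl in place of hydrogen on an oxygen next to a carbonyl group.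

Compound 4 `CCOC(=O)/C=C/c1cc(Cl)ccc1OC(=O)c1nc(C)c(C)nc1C` differs from compound 3 by chloro in place of methoxy on an aromatic carbon. Among the measured compounds shown here, no measured step concerns this exchange or this position; the one recorded step changes the ester oxygen and therefore gives no direction for an aromatic substituent. With nothing pointing either way, the expected step is a number 0.2 percentage points lower from compound 3 to compound 4 (within the scatter), that is, none beyond the scatter. For compound 4 in this assay a value of 46% is estimated, within a range from 28% to 66%.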

Compound 4, a percentage reported as activity, at one concentration (the size of the read-out at that concentration, not a potency): 11%
Compound 4: middle estimate off by 35 percentage points, on the high side; the whole stated range lies above it.
By their numbers in this assay, from the lowest: compound 4; then compounds 3 and 1 (each within the scatter of the next); then compound 2.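

The position para to a large group and meta to the 2-(ethoxycarbonyl)ethenyl group is not silent in this assay: chloro in place of methoxy gives a number 35.2 percentage points lower from compound 3 to compound 4 (beyond the scatter). Among these compounds, until now, the only recorded one-place step was the change at the ester oxygen, a number 33 percentage points lower from compound 2 to compound 3 (beyond the scatter); an exchange on the aromatic carbon now also gives a large step, here with the ethyl ester in place. No measurement available here bears on why this exchange moves the read-out so far, and the loss of methoxy cannot be told apart from the entry of chloro.

Open, from the compounds shown here alone, is whether a bromo group, a methyl group or an amine on this aromatic carbon would give a similar number. Also open, going by these compounds, is whether chloro in place of methoxy gives a step of like size on the carboxylic acid of compound 2.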